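The source may report more compounds than this note shows. Statements on the series, on what has been measured and on what is new or still open speak of the compounds shown alone.

Working notes on the series sharing the core of compound 1 (`Cc1cc(-c2ccc(F)cc2)n(Cc2ccc(C(=O)NO)cc2)n1`) and compound 2 (`CCCc1cc(-c2ccc(F)cc2)n(Cc2ccc(C(=O)NO)cc2)n1`). In a functional assay on A549 cells (Homo sapiens) for antiproliferative activity, read by MTT assay, with a stated time of 96 h (a lower number here means a stronger inhibitor of growth, a higher number a weaker inhibitor of growth), compound 1 gives 33000 nM. For the measured compounds named here, compound 2 gives 16000 nM, the lower of the two numbers so far. Compound 3 (`CCc1cc(-c2ccc(F)cc2)n(Cc2ccc(C(=O)NO)cc2)n1`) departs from compound 2 by hydrogen in place of methyl on a saturated chain carbon, two bonds along the chain from an aromatic carbon, which shortens propyl to ethyl. Going by the values given here, one measured step bears on this, a 2.1-fold lower number from compound 1 to compound 2 (0.31 log units; beyond the scatter), a modest change on the same chain. The ethyl of compound 3 is shorter than the propyl of compound 2 and longer than the methyl of compound 1, so part of that step should be reversed, though two compounds fix no trend. The expected change is a 1.4-fold higher number from compound 2 to compound 3 (0.16 log units; within the scatter), a higher number in this assay but probably within the scatter. For compound 3 the estimated value is 23000 nM, with an expected range of 13000 nM to 38000 nM.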

Compound 3, concentration for 50% growth inhibition: 16700 nM
Estimate against measurement, compound 3: 1.4-fold (0.14 log units) above, and the stated range covers the measured number.
By their numbers in this assay, from the lowest: compounds 2, 3 and 1 (each within the scatter of the next, the first and the last beyond it).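

In this assay, for the compounds shown here, the propyl to ethyl change gives a 1.0-fold higher number from compound 2 to compound 3 (0.02 log units; within the scatter) and the added methyl on the chain of compound 1 gives a 2.0-fold lower number from compound 1 to compound 3 (0.30 log units; within the scatter), so compound 3 lies within the scatter of both other compounds, while only the pair of compound 1 and compound 2 is printed as beyond it. The step that looked like a single modest effect of chain length at this position therefore cannot be assigned to either the ethyl to methyl difference or the propyl to ethyl difference, and three compounds whose neighbours all fall within the scatter fix no trend. Nothing on hand gives a reason for these numbers. As far as these compounds go, whether a longer chain such as butyl, a branched chain such as isopropyl, or a chain ending in an amine or a carboxylic acid would move the number beyond the scatter stays open. Also open, from the compounds shown here alone, is whether the small differences along this chain would hold with other groups on the shared core.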